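A Second Chloro on the Benzyl Ring of Compound 1

The source may report more compounds than this note shows. Statements on the series, on what has been measured and on what is new or still open speak of the compounds shown alone.

Three measured compounds share one core and differ only in what the benzyl ether carries. Compound 1 `N[C@]1(C(=O)O)[C@H]2[C@@H](C[C@H]1OCc1ccccc1Cl)[C@]2(F)C(=O)O` bears a 2-chlorophenyl, compound 2 `N[C@]1(C(=O)O)[C@H]2[C@@H](C[C@H]1OCc1ccccc1-c1ccccc1)[C@]2(F)C(=O)O` has a phenyl in place of that chloro, and compound 3 `N[C@]1(C(=O)O)[C@H]2[C@@H](C[C@H]1OCc1ccc(-c3ccccc3)cc1)[C@]2(F)C(=O)O` carries the phenyl elsewhere on the ring. In an assay on CHO cells for binding affinity to metabotropic glutamate receptor 2 (Rattus norvegicus) (on this read-out lower numbers stand for stronger inhibition and higher numbers for weaker inhibition), compound 1 gives 4.99 nM, compound 2 gives 4.07 nM, and compound 3 gives 25.6 nM. Compound 1 therefore holds the second highest of the three numbers: it sits within the scatter of compound 2, while compound 3 lies beyond the scatter with a clearly higher number.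

The only single-point step among these, a 1.2-fold lower number from compound 1 to compound 2 (0.09 log units; within the scatter), swaps one group for another without moving the number beyond the scatter.

Compound 4 `N[C@]1(C(=O)O)[C@H]2[C@@H](C[C@H]1OCc1cc(Cl)ccc1Cl)[C@]2(F)C(=O)O` is the next step from compound 1: chloro in place of hydrogen on an aromatic carbon. Going by the values given here, no measured step adds a second group to this ring, so the one step available, from compound 1 to compound 2, is only an indirect guide, and it was within the scatter. A small step is therefore expected, a 1.2-fold higher number from compound 1 to compound 4 (0.08 log units; within the scatter), with no clear direction. Compound 4 is estimated at 6 nM, between 2 nM and 18 nM.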

Compound 4, inhibition constant: 11.8 nM
The estimate for compound 4 lay 2.0-fold (0.29 log units) below the measured number, within the range that was stated.
By their numbers in this assay, from the lowest: compounds 2 and 1 (each within the scatter of the next); then compound 4; then compound 3.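

In this assay, a chloro in place of hydrogen on this aromatic carbon, meta to a large group and para to the existing chloro group, gives a 2.4-fold higher number from compound 1 to compound 4 (0.37 log units; beyond the scatter). This is the first step shown that adds a group to the ring rather than exchanging one group for another, and it shows that this carbon does not tolerate every change without consequence: one extra heavy atom is enough to weaken binding to a measurable, though modest, degree. Nothing available explains why the number rises at this position, so the result stands as an observation only.

A single chloro on a single carbon cannot show whether the rise belongs to chloro itself or would follow any group placed there, and a fluoro, a methyl, a methoxy or an amine on that same carbon would each test this. As far as these compounds go, it also remains open whether the step would be the same size on a ring without the original chloro, so the effect of the second chloro cannot yet be separated from the presence of the first.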